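The compounds below may be only part of what the source reports. "The series", "measured", "known", "first", "only" and "open" are said of these compounds alone.

Measured so far in an ADME assay on Akata cells (Homo sapiens) for cytotoxicity, with a stated time of 7 days; on this read-out lower numbers stand for higher toxicity in this test and higher numbers for lower toxicity in this test:

Compound 1 `CCCCCOc1nc(N)nc2c1ncn2/C=C1/CC1(CO)CO` gives a result that is only a limit of the test, > 20000 nM.
Compound 2 `CCCOc1nc(N)nc2c1ncn2/C=C1/CC1(CO)CO` likewise gives only a limit, > 20000 nM.
Compound 3 `CCCCCCOc1nc(N)nc2c1ncn2/C=C1/CC1(CO)CO` also gives only a limit, > 20000 nM.

All three share one core and differ only in the length of the chain on the aromatic oxygen. Compound 3 differs from compound 1 by methyl in place of hydrogen on a saturated chain carbon, five bonds along the chain from an oxygen on an aromatic ring. Compound 2 differs from compound 1 by hydrogen in place of ethyl on a saturated chain carbon, three bonds along the chain from an oxygen on an aromatic ring, and that move produced a step that the two limits leave unreadable from compound 1 to compound 2. Compound 4 `CCCCOc1nc(N)nc2c1ncn2/C=C1/CC1(CO)CO` has not yet been measured in this assay; it differs from compound 3 by hydrogen in place of ethyl on a saturated chain carbon, four bonds along the chain from an oxygen on an aromatic ring. The place differs in its wording, four bonds along the chain instead of three, so this is the same kind of change rather than the same change. Since (the limit of > 20000 nM in this assay, at which 3 of the 3 values shown sit), no chain length shown here has moved the read-out off that limit. The step from compound 3 to compound 4 is therefore expected to be about a step that the limit leaves unreadable from compound 3 to compound 4. The estimated value for compound 4 is 40000 nM, most likely reported again as a limit.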

Compound 4, half-maximal cytotoxic concentration: > 20000 nM
Compound 4: no number, only a limit; the forecaster's own chance of this, stated with the estimate: 90%; the middle value does not contradict the limit.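

In this assay compound 4 gives > 20000 nM, which is only a limit of the test. Among these compounds, no step between compound 4 and compound 1, compound 2 or compound 3 can be read, since each pair has only limits. The compounds shown leave open whether chain length on the shared core changes this read-out at all: the limit of > 20000 nM in this assay, at which 4 of the 4 values shown sit.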